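Methoxy added to compound 2: expected step

This account rests on a few compounds, and the source may have more. Where it says the series, first, only, none or still open, it means among the compounds named here.

Measured so far:
- compound 1 `COc1cccc(/C=C/C(=O)Nc2cc(OC)c(OC)c(OC)c2)c1`: 23400 nM
- compound 2 `C=C(Br)C(=O)Nc1cccc(/C=C/C(=O)Nc2ccc(OC)c(OC)c2)c1`: 21 nM

Both values come from a functional assay on CCRF-CEM cells (Homo sapiens) for inhibition, read by MTT assay, with a stated time of 72 h; on this read-out lower numbers stand for stronger inhibition and higher numbers for weaker inhibition. Compound 2, at 21 nM, holds the lower of the two numbers, and the gap between it and compound 1, at 23400 nM, lies beyond the scatter. These two compounds differ in more than one place, so their gap cannot be assigned to any single change.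

Compound 3 `C=C(Br)C(=O)Nc1cccc(/C=C/C(=O)Nc2cc(OC)c(OC)c(OC)c2)c1` differs from compound 2 in one place: methoxy in place of hydrogen on an aromatic carbon. Among the measured compounds shown here, no measured pair isolates this change, so the expectation rests on judgement alone. In this assay, no step beyond the scatter is expected, and no firm direction can be argued from two values. The estimated step of a 1.1-fold lower number from compound 2 to compound 3 (0.02 log units; within the scatter) therefore stays small. Compound 3 is expected at 20 nM, with an estimated range of 6 nM to 70 nM.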

Compound 3, half-maximal inhibitory concentration: 59 nM
Beside the measured number, compound 3's estimate is 3.0-fold (0.47 log units) below it; the measured number falls inside the stated range.
By their numbers in this assay, from the lowest: compound 2; then compound 3; then compound 1.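

In this assay, methoxy in place of hydrogen on an aromatic carbon, ortho to a methoxy group and meta to a large group, is not a silent change: a 2.8-fold higher number from compound 2 to compound 3 (0.45 log units; beyond the scatter) is a modest loss, and compound 3 stays far closer to compound 2 than to compound 1. The other one-place comparison, ((1-bromoethenyl)carbonyl)amino in place of methoxy on an aromatic carbon, gives a 400-fold lower number from compound 1 to compound 3 (2.60 log units; beyond the scatter) and is the larger of the two steps, so compound 3 now links compound 1 and compound 2 through changes that can each be read alone. Nothing measured in this series gives a reason for either step.

As far as these compounds go, whether the loss belongs to methoxy specifically or to any group at this position remains open, as a hydroxyl, a fluorine or an amine there would be needed to tell these apart. From the compounds shown here alone, it is also open whether the large step depends on the bromine atom of ((1-bromoethenyl)carbonyl)amino, which a comparison with the chlorine analogue or the plain acryloylamino group would address.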